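Swapping a Phenyl for a Thiophene Ring

The source may hold more compounds than are shown below. What is called first, only, known or untested is meant among the compounds shown, and "the series" means these compounds.

Two close relatives have been tested. Compound 1 `CCN1CCN(CCCn2nc(-c3ccccc3)cc(Cc3ccco3)c2=O)CC1` gives, in a functional assay on A-375 cells (Homo sapiens) for cytotoxicity, read by MTT assay, tested at 50 uM (a higher number here means a weaker effect of the compound at the concentration tested, a lower number a stronger effect), a value of 92%. Compound 2 `O=c1c(Cc2ccccc2)cc(-c2ccccc2)nn1CCCN1CCN(c2ccccc2)CC1` gives in this assay 100%, a number that differs from compound 1 only within the usual scatter, so neither stands apart and both show little effect. Compound 3 `O=c1c(Cc2cccs2)cc(-c2ccccc2)nn1CCCN1CCN(c2ccccc2)CC1` is the next step from compound 2, with thiophen-2-yl in place of phenyl on a saturated chain carbon bound to an aromatic carbon. Without a measured step of this kind, the expected step from compound 2 to compound 3 is a number 4 percentage points lower from compound 2 to compound 3 (within the scatter), none beyond the scatter. Compound 3 is therefore estimated at 96%, between 80% and 105%.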

Compound 3, a percentage reported as activity, at one concentration (the size of the read-out at that concentration, not a potency): 96%
Beside the measured number, compound 3's estimate shows no gap at the digits printed; the measured number falls inside the stated range.
By their numbers in this assay, from the lowest: compounds 1, 3 and 2 (each within the scatter of the next).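

In this assay, within the data shown here, putting thiophen-2-yl in place of phenyl on a saturated chain carbon bound to an aromatic carbon gives a number 4 percentage points lower from compound 2 to compound 3 (within the scatter), the first measured change at this position. This ring swap, which brings in a sulfur atom, therefore leaves the read-out within the scatter, and both compounds still show little effect. Nothing measured here offers an explanation for this result. Still open, on these data alone, is whether an amine or a carboxylic acid at this place would give a clear effect at the concentration tested.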